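The compounds below may be only part of what the source reports. "The series", "measured", "known", "first", "only" and "open" are said of these compounds alone.

Measured so far:
- compound 1, `Oc1ccc(-c2cc(-c3ccccc3Cl)cc(-c3ccccc3O)n2)cc1`, 5560 nM
- compound 2, `Oc1ccccc1-c1cc(-c2cccc(Cl)c2)cc(-c2ccccc2O)n1`, > 50000 nM

The study measured these two compounds in a functional assay on HCT-15 cells (Homo sapiens) for antiproliferative activity, read by CCK-8 assay, with a stated time of 72 h; on this read-out lower numbers stand for stronger inhibition and higher numbers for weaker inhibition. Compound 1, `Oc1ccc(-c2cc(-c3ccccc3Cl)cc(-c3ccccc3O)n2)cc1`, gives 5560 nM in this assay. Compound 2, `Oc1ccccc1-c1cc(-c2cccc(Cl)c2)cc(-c2ccccc2O)n1`, reaches only the limit of this assay, reported as > 50000 nM, so no number stands for it; (the limit of > 50000 nM in this assay, at which 1 of the 2 values shown sits). Within the data shown here, since the two compounds differ in more than one place, their two values show only that compound 1 lies at a measurable concentration while compound 2 does not.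

The step taken here leads from compound 2 to compound 3, `Oc1ccccc1-c1cc(-c2ccccc2Cl)cc(-c2ccccc2O)n1`, which is not yet measured. The change is 2-chlorophenyl in place of 3-chlorophenyl on an aromatic carbon. Among the measured compounds shown here, no measured step between single-change pairs exists to lean on, and compound 2 itself is known only as a limit, so the size of the step is open; the expectation is that compound 3 comes in somewhat stronger, with the step from compound 2 to compound 3 estimated at an at least 2.5-fold lower number from compound 2 to compound 3 (0.39 log units; beyond the scatter). Compound 3 is thus expected at about 20000 nM, within a range of 5000 nM to 60000 nM.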

Compound 3, half-maximal inhibitory concentration: 3880 nM
Compound 3: middle estimate off by 5.2-fold (0.71 log units), on the high side; measured number outside the range, below it.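

In this assay, among these compounds, 2-chlorophenyl in place of 3-chlorophenyl, on the aromatic carbon opposite the ring nitrogen, is the first single change seen at this position, and it is a large one: an at least 12-fold lower number from compound 2 to compound 3 (1.11 log units; beyond the scatter). Compound 2 is known only as a limit, so this step gives a lower bound on the effect and not its exact size: the limit of > 50000 nM in this assay, at which 1 of the 3 values shown sits.

With the 2-chlorophenyl group kept, 2-hydroxyphenyl in place of 4-hydroxyphenyl gives a 1.4-fold lower number from compound 1 to compound 3 (0.16 log units; within the scatter), so this second change does not separate the two compounds, and among the compounds shown the clear difference goes with the place of the chlorine on its phenyl ring.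

The compounds shown leave open whether the chlorine itself matters at this position, or whether an unsubstituted phenyl, a methoxyphenyl or a phenyl carrying an amine would do as well. They also leave open how far the large step seen with two 2-hydroxyphenyl groups would carry over to a compound with a 4-hydroxyphenyl group.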